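The source may report more compounds than this note shows. Statements on the series, on what has been measured and on what is new or still open speak of the compounds shown alone.

Measured in a functional assay on U-373MG ATCC cells (Homo sapiens) for inhibition, read by MTT assay, with a stated time of 72 h; a higher number here means a weaker inhibitor, a lower number a stronger inhibitor:
Compound 1 (`COc1ccc(NC(=S)NC2CC(C)(C)Oc3ccc(Br)cc32)cc1`) gives 40000 nM
Compound 2 (`CC1(C)CC(NC(=O)Nc2ccccc2)c2cc(Cl)ccc2O1`) gives 68000 nM

The two values lie within the usual scatter of each other, so compound 2 stands level with compound 1 on these numbers. Going by the values given here, the two compounds also differ in more than one place, and no measured step isolates any single change.

The next compound is compound 3 (`CC(C)NC(=O)NC1CC(C)(C)Oc2ccc(Cl)cc21`). It keeps the core of compound 2 but carries isopropyl in place of phenyl on an amide-type nitrogen, a change from anilino to isopropylamino. Among the compounds with values here, nothing measured so far shows how this assay responds at this place, so only a modest move toward a higher number is expected, and its direction is uncertain. The expected change is a 1.3-fold higher number from compound 2 to compound 3 (0.10 log units; within the scatter) and no more than that. Compound 3 is estimated at 85000 nM with 35000 nM to 200000 nM as its likely range.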

Compound 3, half-maximal inhibitory concentration: 62000 nM
Beside the measured number, compound 3's estimate is 1.4-fold (0.14 log units) above it, within the range that was stated.
By their numbers in this assay, from the lowest: compounds 1, 3 and 2 (each within the scatter of the next).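

In this assay, going by these compounds alone, isopropyl in place of phenyl on an amide-type nitrogen gives a 1.1-fold lower number from compound 2 to compound 3 (0.04 log units; within the scatter) and so provides the first reading of a single change at this place. Removing the six-membered aromatic ring and going from 6 heavy atoms to 3 leaves the two numbers level, so for this pair the phenyl ring is not needed to hold the number where it stands. No measured evidence accompanies this result to account for it.

The compounds shown leave open whether any group on this nitrogen can move the number beyond the scatter. A longer chain such as n-hexyl, or a chain ending in an amine or a carboxylic acid, would test that further.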